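Swapping the Benzyl Substituent on a Nucleoside Core

The compounds below may be only part of what the source reports. "The series", "measured", "known", "first", "only" and "open" are said of these compounds alone.

Of the compounds shown here, three sharing one core have been tested in a functional assay on K562 cells (Homo sapiens) for antiproliferative activity, with a stated time of 72 h; on this read-out higher numbers stand for weaker inhibition and lower numbers for stronger inhibition. Compound 1 `OC[C@H]1O[C@@H](n2cnc3c(NCc4ccc(F)cc4)ncnc32)[C@H](O)[C@@H]1O` gives 2700 nM. Compound 3 `OC[C@H]1O[C@@H](n2cnc3c(NCc4ccc(F)c(Cl)c4)ncnc32)[C@H](O)[C@@H]1O` gives 5500 nM, and the step of a 2.0-fold higher number from compound 1 to compound 3 (0.31 log units; beyond the scatter) shows that adding the chloro costs a little activity. For compound 2 `Cc1cccc(CNc2ncnc3c2ncn3[C@@H]2O[C@H](CO)[C@@H](O)[C@H]2O)c1` only a limit is recorded, > 166000 nM, so its true value is not known. Compound 3 thus has the highest number among the two real values shown, with compound 1 nearest.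

Compound 4 `OC[C@H]1O[C@@H](n2cnc3c(NCc4ccc(C(F)(F)F)cc4)ncnc32)[C@H](O)[C@@H]1O` has not yet been measured. It differs from compound 3 in one place: 4-(trifluoromethyl)phenyl in place of 3-chloro-4-fluorophenyl on a saturated chain carbon bound to a nitrogen on an aromatic ring. Among the measured compounds shown here, the steps that bear on this are a 2.0-fold higher number from compound 1 to compound 3 (0.31 log units; beyond the scatter), which is modest, and the large steps of an at least 61-fold higher number from compound 1 to compound 2 (1.78 log units; beyond the scatter) and an at least 30-fold lower number from compound 2 to compound 3 (1.47 log units; beyond the scatter), which show that the group on this saturated chain carbon can move the number a great deal. From the compounds shown here alone, removing the chloro would be expected to recover a little, while the trifluoromethyl is untested here, so compound 4 is expected to land near compound 3 with a step of a 1.1-fold lower number from compound 3 to compound 4 (0.04 log units; within the scatter), giving an estimated 5000 nM with a range from 1500 nM to 40000 nM.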

Compound 4, half-maximal inhibitory concentration: > 166000 nM
Compound 4: only a limit was reported; the forecaster's own chance of this, stated with the estimate: 10%; middle value at least 33-fold (1.52 log units) from the limit.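

A single swap on an aromatic carbon, trifluoromethyl in place of fluoro, gives an at least 61-fold higher number from compound 1 to compound 4 (1.78 log units; beyond the scatter) in this assay, and replacing the whole 3-chloro-4-fluorophenyl group gives an at least 30-fold higher number from compound 3 to compound 4 (1.47 log units; beyond the scatter). Compound 2 is therefore no longer the only case of so large a loss: it also occurs without the 3-methylphenyl group, whereas adding a chloro to compound 1 to give compound 3 moved the number only modestly. Compound 4, like compound 2, has only a limit, so the step connecting them cannot be read and the true size of the loss stays unknown: the limit of > 166000 nM in this assay, at which 2 of the 4 values shown sit.

From the compounds shown here alone, it remains open whether a methoxy, a nitrile or a methyl on that same aromatic carbon would stay close to compound 1 or also fall to the limit. The compounds shown also do not tell whether the unsubstituted phenyl group would keep any activity.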